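Estimating a Cyanophenyl Amide From Three Measured Analogues

This account rests on a few compounds, and the source may have more. Where it says the series, first, only, none or still open, it means among the compounds named here.

Three compounds have been measured in a functional assay on A549 cells (Homo sapiens) for inhibition, read by CCK-8 assay, with a stated time of 72 h, tested at 10 uM; a higher number here means more inhibition of growth at the concentration tested, a lower number less inhibition of growth:

compound 1 `CN(C)C(=O)c1cc2cnc(Nc3ccc(NC(=O)C4(C(=O)Nc5ccccc5F)CC4)cc3)nc2n1C1CCCC1` gives 88.6%
compound 2 `CN(C)C(=O)c1cc2cnc(Nc3ccc(NC(=O)C4(C(=O)Nc5cccc(Br)c5)CC4)cc3)nc2n1C1CCCC1` gives 92.2%
compound 3 `COc1ccc(NC(=O)C2(C(=O)Nc3ccc(Nc4ncc5cc(C(=O)N(C)C)n(C6CCCC6)c5n4)cc3)CC2)cc1` gives 78.5%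

Compound 2 has the highest of these three numbers. Compound 1 sits close to it, the step being a number 3.6 percentage points higher from compound 1 to compound 2 (within the scatter), so the two cannot be told apart. Compound 3 lies clearly lower, with a number 13.7 percentage points lower from compound 2 to compound 3 (beyond the scatter) and, from the other side, a number 10.1 percentage points lower from compound 1 to compound 3 (beyond the scatter).

Compound 4 `CN(C)C(=O)c1cc2cnc(Nc3ccc(NC(=O)C4(C(=O)Nc5ccc(C#N)cc5)CC4)cc3)nc2n1C1CCCC1` has not yet been measured. It differs from compound 2 in one place: 4-cyanophenyl in place of 3-bromophenyl on an amide-type nitrogen.

Among the measured compounds shown here, two measured steps bear on this change. Both steps that end at compound 3 show that replacing the halogenated phenyl ring on that amide-type nitrogen with a 4-methoxyphenyl costs a modest amount beyond the scatter. The step from compound 1 to compound 2 shows that exchanging one halogenated phenyl for another changes nothing beyond the scatter. For the measured compounds named here, no measured compound carries a 4-cyanophenyl in this place, so the direction for a nitrile is not fixed by the data. The step from compound 2 to compound 4 is therefore expected to be small, probably downward, around a number 8.2 percentage points lower from compound 2 to compound 4 (within the scatter), and possibly within the scatter.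

Compound 4 is estimated at 84%, within a range of 72% to 94%.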

Compound 4, percent growth inhibition at one concentration: 95%
Compound 4: middle estimate off by 11 percentage points, on the low side; measured number above the stated range.
By their numbers in this assay, from the lowest: compound 3; then compounds 1, 2 and 4 (each within the scatter of the next).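

In this assay, a ring without a halogen proved able to sit on this amide-type nitrogen without leaving the range of the halogenated rings, with a number 2.8 percentage points higher from compound 2 to compound 4 (within the scatter) and a number 6.4 percentage points higher from compound 1 to compound 4 (within the scatter). The direct comparison of the two non-halogenated rings gives a number 16.5 percentage points higher from compound 3 to compound 4 (beyond the scatter). Among the compounds shown here, neither ring carries a halogen and both carry a group in the printed 4-substituted form, yet 4-cyanophenyl and 4-methoxyphenyl part ways, and compound 3 is the one compound that stands apart from the other three. Nothing measured here accounts for that difference between the nitrile and the methoxy group.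

Compounds 1, 2 and 4 all lie within the scatter of one another at a single tested concentration, so this read-out leaves any ranking among them unsettled. The compounds shown also leave open how this position would respond to a 4-aminophenyl, a 4-carboxyphenyl or a cyclohexyl group on the same nitrogen, and whether the nitrile would behave alike on a ring carrying it in another place.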